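The source may hold more compounds than are shown below. What is called first, only, known or untested is meant among the compounds shown, and "the series" means these compounds.

Compound 1 `CC1(C)Oc2ccc(C#N)cc2[C@@H](NC(=O)Nc2ccccc2)[C@@H]1O`: 800 nM
Compound 2 `CC1(C)Oc2ccc(C#N)cc2[C@@H](/N=C(\NC#N)Nc2cccc([N+](=O)[O-])c2)[C@@H]1O`: 670 nM

In a functional assay (aorta) with Rattus norvegicus as the target (on this read-out lower numbers stand for stronger inhibition and higher numbers for weaker inhibition), compound 1 gives 800 nM and compound 2 gives 670 nM; the two numbers sit within the usual scatter of each other, so neither can be called the stronger. Compound 3 `Cc1ccc(N/C(=N/[C@@H]2c3cc(C#N)ccc3OC(C)(C)[C@H]2O)NC#N)cc1C` differs from compound 2 by 3,4-dimethylphenyl in place of 3-nitrophenyl on an amine nitrogen. Among the measured compounds shown here, no comparison between measured compounds informs this exchange of a 3-nitrophenyl for a 3,4-dimethylphenyl. The expected step in this assay from compound 2 to compound 3 is small, near the scatter, leaning toward weaker inhibition, as a 1.3-fold higher number from compound 2 to compound 3 (0.13 log units; within the scatter). Compound 3 is estimated at 900 nM, within 300 nM to 3000 nM.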

Compound 3, half-maximal inhibitory concentration: 5100 nM
Compound 3: the middle estimate sits 5.7-fold (0.75 log units) below what was measured; the whole stated range lies below it.
By their numbers in this assay, from the lowest: compounds 2 and 1 (each within the scatter of the next); then compound 3.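

In this assay the aryl group on this amine nitrogen clearly counts: 3,4-dimethylphenyl in place of 3-nitrophenyl gives a real loss of inhibition (a 7.6-fold higher number from compound 2 to compound 3 (0.88 log units; beyond the scatter)). Among the compounds shown here, the position therefore does not treat these two substituted phenyl groups alike, which the earlier compounds could not show. No available data explain why. On these data alone, it remains open whether the step follows from losing the nitro group or from adding the two methyl groups. A methoxy group or a chlorine on the phenyl ring could help separate these possibilities.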